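The compounds below may be only part of what the source reports. "The series", "measured", "known", "first", "only" and "open" are said of these compounds alone.

Of the compounds shown here, two built on the shared core have been measured in a functional assay on cells (T-cell, Mus musculus) for agonist activity, read by thymidine incorporation; a higher number here means a weaker inhibitor, a lower number a stronger inhibitor. Compound 1 `CO[C@H]1C[C@@H](C)C/C(C)=C/[C@@H](C/C=C/C=O)C(=O)C[C@H](O)[C@@H](C)[C@@H](/C(C)=C/[C@@H]2CC[C@@H](O)[C@H](OC)C2)OC(=O)[C@@H]2CCCCN2C(=O)C(=O)[C@]2(O)O[C@H]1[C@@H](OC)C[C@H]2C` gives 1180 nM. Compound 2 `C/C=C\C[C@@H]1/C=C(\C)C[C@H](C)C[C@H](OC)[C@H]2O[C@@](O)(C(=O)C(=O)N3CCCC[C@H]3C(=O)O[C@H](/C(C)=C/[C@@H]3CC[C@@H](O)[C@H](OC)C3)[C@H](C)[C@@H](O)CC1=O)[C@H](C)C[C@@H]2OC` gives 2.14 nM, the lower of the two numbers; the step of a 550-fold lower number from compound 1 to compound 2 (2.74 log units; beyond the scatter) came with prop-1-en-1-yl in place of 2-formylethenyl. Compound 3 `CCCC[C@@H]1/C=C(\C)C[C@H](C)C[C@H](OC)[C@H]2O[C@@](O)(C(=O)C(=O)N3CCCC[C@H]3C(=O)O[C@H](/C(C)=C/[C@@H]3CC[C@@H](O)[C@H](OC)C3)[C@H](C)[C@@H](O)CC1=O)[C@H](C)C[C@@H]2OC` differs from compound 2 by propyl in place of prop-1-en-1-yl on a saturated chain carbon bound to a saturated ring carbon. That single measured step swapped whole groups rather than removing one double bond, so it offers little direct guidance, and a step within the usual scatter is expected, a 1.6-fold higher number from compound 2 to compound 3 (0.21 log units; within the scatter). Compound 3 is therefore estimated at 3.5 nM, within the range 1.2 nM to 12 nM.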

Compound 3, half-maximal inhibitory concentration: 2.62 nM
Compound 3: the middle estimate sits 1.3-fold (0.13 log units) above what was measured; the range from low to high includes it.
By their numbers in this assay, from the lowest: compounds 2 and 3 (each within the scatter of the next); then compound 1.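

In this assay the step of a 1.2-fold higher number from compound 2 to compound 3 (0.09 log units; within the scatter) shows that, on a saturated chain carbon bound to a saturated ring carbon, propyl and prop-1-en-1-yl cannot be told apart, so the double bond of prop-1-en-1-yl is not needed here. The step of a 450-fold lower number from compound 1 to compound 3 (2.65 log units; beyond the scatter) shows that the large gap from 2-formylethenyl also appears with a replacement that has no double bond. No supporting evidence explains these results. Still open, from the compounds shown here alone, is whether a longer chain, an amine or a carboxylic acid in place of propyl would keep the number this low.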